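Cyanobenzyl in Place of a tert-Butyl Ester on a Sulfonamide

This account rests on a few compounds, and the source may have more. Where it says the series, first, only, none or still open, it means among the compounds named here.

Of the compounds shown here, three have been measured in an in vitro ADME assay on microsomes from liver (Mus musculus) for metabolic stability; on this read-out higher numbers stand for a longer-lived compound and lower numbers for a shorter-lived compound. Compound 1 `Cn1cnc(S(=O)(=O)N(CC(=O)OC(C)(C)C)C2Cc3cc(C#N)ccc3N(Cc3cncn3C)C2)c1` carries a (tert-butoxycarbonyl)methyl group on its sulfonamide nitrogen and gives 10 h in this assay, the lowest of the three numbers. Compound 3 `Cn1cnc(S(=O)(=O)N(CC(=O)OC(C)(C)C)C2Cc3cc(C#N)ccc3N(Cc3cncn3C)C2=O)c1` carries the same group on a core that differs from the core of compound 1; the difference between the two cores is not broken down here. In this assay compound 3 gives 21 h, a higher number than compound 1 by a step beyond the usual scatter. Compound 2 `Cn1cnc(S(=O)(=O)N(Cc2ccc(C#N)cc2)C2Cc3cc(C#N)ccc3N(Cc3cncn3C)C2=O)c1` shares the core of compound 3 and differs from it in one place: 4-cyanophenyl in place of tert-butoxycarbonyl on a saturated chain carbon bound to a sulfonamide nitrogen. This change made a step of a 1.9-fold higher number from compound 3 to compound 2 (0.28 log units; within the scatter), so that compound 2 reaches 40 h in this assay.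

Compound 4 `Cn1cnc(S(=O)(=O)N(Cc2ccc(C#N)cc2)C2Cc3cc(C#N)ccc3N(Cc3cncn3C)C2)c1` has not yet been measured. It stands to compound 1 as compound 2 stands to compound 3, the same change at the same place: 4-cyanophenyl in place of tert-butoxycarbonyl on a saturated chain carbon bound to a sulfonamide nitrogen. Among the compounds shown this change occurs twice in all, and its one measured instance, on the core of compound 3, stayed within the scatter. On that single precedent compound 4 is expected to move by a 1.8-fold higher number from compound 1 to compound 4 (0.26 log units; within the scatter) in this assay. Within the data shown here, the half-life of compound 4 in this assay is therefore estimated at 18 h, between 8 h and 40 h, a range kept wide because the only measured guide is a 1.9-fold higher number from compound 3 to compound 2 (0.28 log units; within the scatter) on a different core.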

Compound 4, half-life: 3 h
The estimate for compound 4 lay 6.0-fold (0.78 log units) above the measured number, outside the stated range (below it).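

In this assay, putting 4-cyanophenyl in place of tert-butoxycarbonyl on a saturated chain carbon bound to a sulfonamide nitrogen gave a 3.3-fold lower number from compound 1 to compound 4 (0.52 log units; beyond the scatter), a step beyond the usual scatter on the core of compound 1. In this series, the result of the change therefore did not carry over from one core to the other as a fixed step, and the measured step on one core did not predict the step on the other: the same change on two cores in this assay, a 1.9-fold higher number (0.28 log units; within the scatter) from compound 3 to compound 2 and a 3.3-fold lower number (0.52 log units; beyond the scatter) from compound 1 to compound 4, 6.3-fold (0.80 log units) apart, beyond the scatter of two such steps. Among these compounds, this rests on only one matched pair for each core, so it shows that the result of this change depends on the core in these compounds, but it does not show which feature of the cores is responsible or how the change would behave on any further core.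

The compounds shown leave open how a plain benzyl group without the nitrile, or a carboxylic acid in place of the tert-butoxycarbonyl, would behave at the same place on each of the two cores. They also leave open which part of the exchange from (tert-butoxycarbonyl)methyl to 4-cyanobenzyl accounts for the different outcomes on the two cores, as the two groups differ in several features at once.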